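Ester series: aromatic nitrogen substituent changed to isopropyl

The source may report more compounds than this note shows. Statements on the series, on what has been measured and on what is new or still open speak of the compounds shown alone.

Compound 1 `CCOC(=O)c1ccc(-c2nn(Cc3ccc(F)cc3)c3ccccc23)cc1` carries a 4-fluorobenzyl group on the aromatic nitrogen of its core. In a functional assay on cells (Platelet, Homo sapiens) for inhibition (on this read-out higher numbers stand for weaker inhibition and lower numbers for stronger inhibition), compound 1 gives > 10000 nM, which is a limit of the assay and not a number. Compound 2 `CCOC(=O)c1cccc(-c2nn(Cc3ccccc3)c3ccccc23)c1` is the related ester with a benzyl group in that position and the ester on a different position of its phenyl ring. In this assay compound 2 gives > 10000 nM, again a limit rather than a number. Going by the values given here, both measured values therefore sit at the limit of > 10000 nM in this assay, at which 2 of the 2 values shown sit, so no step between measured compounds can be computed, and compound 1 cannot be ordered against compound 2 on these numbers.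

Compound 3 `CCOC(=O)c1ccc(-c2nn(C(C)C)c3ccccc23)cc1` is not yet measured. It differs from compound 1 by isopropyl in place of 4-fluorobenzyl on an aromatic nitrogen. Among the compounds with values here, with no measured step available and both known compounds at the limit, the expected step that the limit leaves unreadable from compound 1 to compound 3 is small, none beyond the scatter. Compound 3 is estimated at 15000 nM, within 4000 nM to 60000 nM, and is expected most probably to be reported again only as a limit in this assay.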

Compound 3, half-maximal inhibitory concentration: > 10000 nM
Compound 3: only a limit was reported; the forecaster's own chance of this, stated with the estimate: 80%; the middle value does not contradict the limit.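

In this assay compound 3 gives > 10000 nM, a limit and not a number. Compound 1 also stands only at a limit, so no step can be read between compound 1 and compound 3: the limit of > 10000 nM in this assay, at which 3 of the 3 values shown sit.

The compounds shown leave open how strongly any of these esters inhibits, and which change to the shared core would give a readable value.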